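From a propyl side chain to a cyclobutyl amide

The source may hold more compounds than are shown below. What is called first, only, known or untested is meant among the compounds shown, and "the series" means these compounds.

In a functional assay on HCT-116 cells (Homo sapiens) for antiproliferative activity, read by sulforhodamine B assay, with a stated time of 72 h (on this read-out higher numbers stand for weaker inhibition and lower numbers for stronger inhibition), compound 3 (`CCC[C@@H]1C[C@@H](c2ccc(Cl)c(Cl)c2)[C@H](NC(=O)c2cc(-c3c(Cl)cnn3C)c(Cl)o2)CN1`) gives 1020 nM. That value lies within the usual scatter of compound 1 (`Cn1ncc(Cl)c1-c1cc(C(=O)N[C@@H]2CN[C@H](CC(N)=O)C[C@H]2c2ccc(Cl)c(Cl)c2)oc1Cl`), which gives 650 nM. Compound 2 (`Cn1ncc(Cl)c1-c1cc(C(=O)N[C@@H]2CN[C@H](CC(=O)NCC(O)CO)C[C@H]2c2ccc(Cl)c(Cl)c2)oc1Cl`) gives 7090 nM, the weakest of the three.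

Compound 4 (`Cn1ncc(Cl)c1-c1cc(C(=O)N[C@@H]2CN[C@H](CC(=O)NC3CCC3)C[C@H]2c2ccc(Cl)c(Cl)c2)oc1Cl`) carries cyclobutylcarbamoyl in place of ethyl on a saturated chain carbon bound to a saturated ring carbon.

Two measured steps change this same place, both ending in ethyl. With plain carbamoyl leaving, a 1.6-fold higher number from compound 1 to compound 3 (0.20 log units; within the scatter), so the exchange made no clear difference. With (2,3-dihydroxypropyl)carbamoyl leaving, a 7.0-fold lower number from compound 2 to compound 3 (0.84 log units; beyond the scatter), a modest gain. A third step shows that a group on the amide-type nitrogen can matter: with 2,3-dihydroxypropyl in place of hydrogen there, an 11-fold higher number from compound 1 to compound 2 (1.04 log units; beyond the scatter), a large loss. Within the data shown here, only that one group has been tried on this nitrogen, and no measured compound carries cyclobutylcarbamoyl.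

A change beyond the scatter is therefore not expected, although the uncertainty is wider on the weaker side. The estimated step is a 1.1-fold lower number from compound 3 to compound 4 (0.05 log units; within the scatter). For compound 4 the expected value is 900 nM, with an estimated range from 300 nM to 2800 nM.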

Compound 4, half-maximal inhibitory concentration: 430 nM
The estimate for compound 4 lay 2.1-fold (0.32 log units) above the measured number; the range from low to high includes it.
By their numbers in this assay, from the lowest: compounds 4, 1 and 3 (each within the scatter of the next, the first and the last beyond it); then compound 2.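

Among these compounds, on the amide-type nitrogen, 2,3-dihydroxypropyl had been the only group seen, and it weakened inhibition; cyclobutyl gives a different picture in this assay. Cyclobutyl in place of hydrogen gives a 1.5-fold lower number from compound 1 to compound 4 (0.18 log units; within the scatter) and so makes no clear difference, while cyclobutyl in place of 2,3-dihydroxypropyl gives a 16-fold lower number from compound 2 to compound 4 (1.22 log units; beyond the scatter) and recovers all of the ground lost with that group. Against the plain propyl chain, moving to (cyclobutylcarbamoyl)methyl gives a 2.4-fold lower number from compound 3 to compound 4 (0.38 log units; beyond the scatter) as a modest gain, which shows that this place on a saturated chain carbon bound to a saturated ring carbon accepts a substituted amide with a ring of carbon only and that the size of the entering group alone does not decide the outcome, since compound 2 carries a large group and goes the other way.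

On these data alone, it remains open whether a cyclopropyl, a cyclohexyl, a 2-hydroxyethyl or a plain butyl chain on this nitrogen would behave like cyclobutyl or like 2,3-dihydroxypropyl. Nothing measured beyond these cell numbers explains the differences among the four compounds.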